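This account rests on a few compounds, and the source may have more. Where it says the series, first, only, none or still open, it means among the compounds named here.

Measured in a functional assay on HBL-100 cells (Homo sapiens) for inhibition, read by sulforhodamine B assay, with a stated time of 48 h; a higher number here means a weaker inhibitor of growth, a lower number a stronger inhibitor of growth:
- Compound 1 `O=C(CCC(F)(F)C(F)(F)C(F)(F)C(F)(F)F)NCCCCCCCCCN[C@@H]1[C@H](O)[C@@H](O)[C@H](O)[C@H]2COC(=O)N21`: > 100000 nM, a limit of the assay
- Compound 2 `O=C(CCC(F)(F)C(F)(F)C(F)(F)C(F)(F)C(F)(F)C(F)(F)F)NCCCCCCCCCN[C@@H]1[C@H](O)[C@@H](O)[C@H](O)[C@H]2COC(=O)N21`: 16000 nM
- Compound 3 `O=C(CCC(F)(F)C(F)(F)C(F)(F)C(F)(F)F)NCCCCCCCCCN[C@@H]1[C@H](O)[C@@H](O)[C@@H](O)[C@H]2COC(=O)N21`: > 100000 nM, a limit of the assay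

Compound 3 has no numerical value, only the limit shown. Its standing is therefore defined by the limit of > 100000 nM in this assay, at which 2 of the 3 values shown sit.

Compound 4 `O=C(CCC(F)(F)C(F)(F)C(F)(F)C(F)(F)C(F)(F)C(F)(F)F)NCCCCCCCCCN[C@@H]1[C@H](O)[C@@H](O)[C@@H](O)[C@H]2COC(=O)N21` follows from compound 3 by one structural change: 1,1,2,2,2-pentafluoroethyl in place of fluoro on a saturated chain carbon bound to two fluorine atoms and a saturated chain carbon. In words, this is 1,1,2,2,2-pentafluoroethyl in place of fluoro on a saturated chain carbon bound to two fluorine atoms and a saturated chain carbon.

The same change has been measured once, in the other configuration: an at least 6.2-fold lower number from compound 1 to compound 2 (0.79 log units; beyond the scatter). That step lies beyond the scatter. The second relevant step, a step that the two limits leave unreadable from compound 1 to compound 3, gives no readable size. What connects the two pairs is the fact that compounds 1 and 3 differ only in the configuration as drawn. Whether the change carries over unchanged to the configuration of compound 3 has not been measured.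

A step of at least modest size towards a lower number is nevertheless expected in this assay, with compound 2 at 16000 nM as the closest guide. The expected step is an at least 5.0-fold lower number from compound 3 to compound 4 (0.69 log units; beyond the scatter). For compound 4 the estimated value is 20000 nM, with an expected range of 6000 nM to 100000 nM.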

Compound 4, concentration for 50% growth inhibition: 16000 nM
The estimate for compound 4 lay 1.3-fold (0.10 log units) above the measured number; low and high end bracket the measured number.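

In this assay, the change from fluoro to 1,1,2,2,2-pentafluoroethyl on a saturated chain carbon bound to two fluorine atoms and a saturated chain carbon now also reads in the second configuration: an at least 6.2-fold lower number from compound 3 to compound 4 (0.79 log units; beyond the scatter). For the compounds shown here, the effect of the drawn configuration also becomes readable for the first time, with no change at the digits printed from compound 2 to compound 4 (within the scatter), so within this one pair the configuration at that saturated ring carbon does not separate the two compounds, which differ in nothing else: the fact that compounds 2 and 4 differ only in the configuration as drawn. The corresponding comparison with fluoro in place of 1,1,2,2,2-pentafluoroethyl cannot be read, because compound 1 and compound 3 both stand at a limit: the limit of > 100000 nM in this assay, at which 2 of the 4 values shown sit.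

On these data alone, whether the size of the change differs between the two configurations stays open: the same change on two cores in this assay, an at least 6.2-fold lower number (0.79 log units; beyond the scatter) from compound 1 to compound 2 and an at least 6.2-fold lower number (0.79 log units; beyond the scatter) from compound 3 to compound 4; the limit leaves it open whether they differ Also open is how this assay would read with a longer perfluoroalkyl chain or with a carboxylic acid in place of fluoro on that saturated chain carbon.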